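Working notes: aryl change from compound 3 to compound 4

The source may hold more compounds than are shown below. What is called first, only, known or untested is meant among the compounds shown, and "the series" means these compounds.

Measured compounds, in a functional assay on PC-3 cells (Homo sapiens) for antiproliferative activity, read by MTT assay; on this read-out lower numbers stand for stronger inhibition and higher numbers for weaker inhibition:
- compound 1 `Cn1c(=O)c(=O)n(C2CCCC2)c2nc(N/N=C/c3ccc(F)c(Cl)c3)ncc21`: 8550 nM
- compound 2 `Cn1c(=O)c(=O)n(C2CCCC2)c2nc(N/N=C/c3ccc(O)c(F)c3)ncc21`: 85200 nM
- compound 3 `Cn1c(=O)c(=O)n(C2CCCC2)c2nc(N/N=C/c3ccc(F)cc3Br)ncc21`: 9250 nM

Compound 3 stands second highest of the three numbers in this assay; its nearest neighbour is compound 1 (a 1.1-fold higher number from compound 1 to compound 3 (0.03 log units; within the scatter)), its furthest compound 2 (a 9.2-fold lower number from compound 2 to compound 3 (0.96 log units; beyond the scatter)). Compound 4 `Cn1c(=O)c(=O)n(C2CCCC2)c2nc(N/N=C/c3ccccc3Cl)ncc21` carries 2-chlorophenyl in place of 2-bromo-4-fluorophenyl on a carbon with a double bond to nitrogen. Within the data shown here, the only step that exchanges one halogenated phenyl for another is a 1.1-fold higher number from compound 1 to compound 3 (0.03 log units; within the scatter), within the scatter; the steps beyond the scatter, a 10-fold higher number from compound 1 to compound 2 (1.00 log units; beyond the scatter) and a 9.2-fold lower number from compound 2 to compound 3 (0.96 log units; beyond the scatter), both involve the 3-fluoro-4-hydroxyphenyl compound and do not bear on a halogen-only change. For compound 4 in this assay no step beyond the scatter is therefore expected, a 1.3-fold higher number from compound 3 to compound 4 (0.11 log units; within the scatter). Compound 4 is estimated at 12000 nM, range 5000 nM to 30000 nM.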

Compound 4, half-maximal inhibitory concentration: 16300 nM
Estimate against measurement, compound 4: 1.4-fold (0.13 log units) below, and the stated range covers the measured number.
By their numbers in this assay, from the lowest: compounds 1, 3 and 4 (each within the scatter of the next); then compound 2.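

In this assay the 2-chlorophenyl group gives a 1.8-fold higher number from compound 3 to compound 4 (0.25 log units; within the scatter) and a 1.9-fold higher number from compound 1 to compound 4 (0.28 log units; within the scatter) and so cannot be told apart from the two other halogenated phenyl groups on this carbon with a double bond to nitrogen. The fluorine of the 2-bromo-4-fluorophenyl group is thus not needed to hold the number in this range. With a 5.2-fold lower number from compound 2 to compound 4 (0.72 log units; beyond the scatter) the 3-fluoro-4-hydroxyphenyl group again sits apart from the halogenated phenyl groups, and no measurement on hand accounts for this.

Open, from the compounds shown here alone, is how an unsubstituted phenyl, or a phenyl carrying a methoxy group, an amine or a carboxylic acid, would compare on this carbon.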